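The compounds below may be only part of what the source reports. "The series", "measured", "known", "first", "only" and "open" are said of these compounds alone.

Compound 3 `Cc1nc(-c2ccccc2F)sc1COc1ccc2c(c1)OCC2CC(=O)O` gives 25.8% in a functional assay on CHO cells for agonist activity at Free fatty acid receptor 1 (Homo sapiens), read by FLIPR and calcium flux, tested at 100 nM (a lower number here means a weaker effect, a higher number a stronger effect of the compound at the concentration tested), the second highest of the three numbers: compound 1 `Cc1nc(-c2ccccc2)sc1COc1ccc2c(c1)OCC2CC(=O)O` gives 54.8% and compound 2 `Cc1nc(-c2cc3ccccc3o2)sc1COc1ccc2c(c1)OCC2CC(=O)O` gives 14.8%. Compound 4 `Cc1nc(-c2cccc(C(F)(F)F)c2)sc1COc1ccc2c(c1)OCC2CC(=O)O` differs from compound 3 by 3-(trifluoromethyl)phenyl in place of 2-fluorophenyl on an aromatic carbon. Within the data shown here, two measured steps bear on this change of the aryl group: a number 29 percentage points lower from compound 1 to compound 3 (beyond the scatter) and a number 11 percentage points higher from compound 2 to compound 3 (beyond the scatter). Both changed the group on the same aromatic carbon of the shared core, yet neither introduced 3-(trifluoromethyl)phenyl, so the direction for compound 4 is uncertain. Considering the large fall in a number 40 percentage points lower from compound 1 to compound 2 (beyond the scatter) when the group was enlarged, a modest change is expected for compound 4, a number 4.2 percentage points higher from compound 3 to compound 4 (within the scatter). Compound 4 is therefore estimated to give about 30%, within 8% to 60%.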

Compound 4, a percentage reported as activity, at one concentration (the size of the read-out at that concentration, not a potency): 35.7%
The estimate for compound 4 lay 5.7 percentage points below the measured number; the measured number falls inside the stated range.
By their numbers in this assay, from the lowest: compound 2; then compounds 3 and 4 (each within the scatter of the next); then compound 1.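

In (this assay), a substituted phenyl group at this place again falls short of the plain phenyl of compound 1, now with 3-(trifluoromethyl)phenyl (a number 19.1 percentage points lower from compound 1 to compound 4 (beyond the scatter)), while it stands clear of 1-benzofuran-2-yl (a number 20.9 percentage points higher from compound 2 to compound 4 (beyond the scatter)). Exchanging 2-fluorophenyl for 3-(trifluoromethyl)phenyl makes no difference that can be read (a number 9.9 percentage points higher from compound 3 to compound 4 (within the scatter)), so the two substituted phenyl groups cannot be told apart here. Nothing at hand explains these steps. From the compounds shown here alone, whether a methoxy group or an amine on the phenyl ring would keep the number of compound 1 stays open, as does the effect of a single fluoro group at the position held by trifluoromethyl in compound 4.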